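Swapping a Methylsulfanyl Group for a Selenium Benzyl Group

This account rests on a few compounds, and the source may have more. Where it says the series, first, only, none or still open, it means among the compounds named here.

Compound 1, `CS/C(=N\C(=O)c1csc([N+](=O)[O-])c1)NC(=O)c1csc([N+](=O)[O-])c1`, gives > 100000 nM in a functional assay on K562 cells (Homo sapiens) for cytotoxicity, read by MTT assay, with a stated time of 72 h (on this read-out lower numbers stand for higher toxicity in this test and higher numbers for lower toxicity in this test), and that value is a limit of the assay, not a number.
Compound 2, `CS/C(=N\C(=O)c1ccno1)NC(=O)c1ccno1`, gives > 100000 nM in this assay, again a limit.
Compound 3, `O=C(/N=C(/NC(=O)c1ccno1)[Se]Cc1ccccc1)c1ccno1`, gives 94700 nM in this assay.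

Compound 3 differs from compound 2 in one place: a group of 8 heavy atoms (7 carbon, 1 selenium; one six-membered aromatic ring of carbon only) in place of a group of 2 heavy atoms (1 carbon, 1 sulfur; no ring), on a carbon with a double bond to nitrogen. That change produced an at least 1.0-fold lower number from compound 2 to compound 3 (0.02 log units; that floor lies within the scatter), so the two compounds sit within the scatter of each other, and the limit of > 100000 nM in this assay, at which 2 of the 3 values shown sit, caps what can be read from compound 2 anyway. Compound 4, `O=C(/N=C(/NC(=O)c1csc([N+](=O)[O-])c1)[Se]Cc1ccccc1)c1csc([N+](=O)[O-])c1`, carries the same change on the core of compound 1: a group of 8 heavy atoms (7 carbon, 1 selenium; one six-membered aromatic ring of carbon only) in place of a group of 2 heavy atoms (1 carbon, 1 sulfur; no ring), on a carbon with a double bond to nitrogen. The difference between the two cores, that of compound 1 and that of compound 2, is not broken down here.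

Compound 1 sits at the limit, and the same change elsewhere gave only an at least 1.0-fold lower number from compound 2 to compound 3 (0.02 log units; that floor lies within the scatter). On that footing compound 4 is expected to move by a number no higher from compound 1 to compound 4 (the limit leaves the size open). The estimated value for compound 4 in this assay is 100000 nM, with an expected spread from 50000 nM to 300000 nM, and a limit rather than a number is quite likely.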

Compound 4, concentration lethal to 50% of the cells: 88200 nM
For compound 4 the middle estimate is 1.1-fold (0.05 log units) above the measured one; measured number inside the range.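

On the core of compound 1, putting the selenium benzyl group in place of the methylsulfanyl group gives an at least 1.1-fold lower number from compound 1 to compound 4 (0.05 log units; that floor lies within the scatter) in this assay, so this step can be read only as a floor. Set beside the same change on the core of compound 2, it shows two floors that both lie within the scatter, and no sign that the core matters, but it does not show that the change has the same size on both cores: the same change on two cores in this assay, an at least 1.0-fold lower number (0.02 log units; that floor lies within the scatter) from compound 2 to compound 3 and an at least 1.1-fold lower number (0.05 log units; that floor lies within the scatter) from compound 1 to compound 4; the limit leaves it open whether they differ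

The true size of each step stays unknown because compound 1 and compound 2 both carry a limit of the assay rather than a number: the limit of > 100000 nM in this assay, at which 2 of the 4 values shown sit.

The compounds shown leave open how this change reads on a core whose starting compound gives a number in this assay rather than a limit. They also leave open how a selenium methyl group, a sulfur benzyl group or an amine on that same carbon would read, and the first two would separate the selenium from the ring.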